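Thiazole to methylated isothiazole on the shared core

A few compounds are considered here, and "the series" means these few. Any claim that something is new, unique, unknown or untested is made for them only; others in the source may bear on it.

For the measured compounds named here, compound 2 `c1ccc(-c2nccs2)c(OCC2=NCCN2)c1` is the only compound with a number: in a functional assay for activation of Alpha-1D adrenergic receptor (Homo sapiens), read by calcium flux (on this read-out higher numbers stand for an effect only at larger amounts of compound and lower numbers for an effect already at smaller amounts), compound 2 gives 31.6 nM. Going by the values given here, compound 1 `c1ccc(-c2cnccn2)c(OCC2=NCCN2)c1` is the only measured neighbour of compound 2. In this assay compound 1 gives a limit of the assay, < 100000 nM. Among the compounds with values here, the step that the limit leaves unreadable from compound 1 to compound 2 is therefore the only measured step, and its size cannot be read because of the limit of < 100000 nM in this assay, at which 1 of the 2 values shown sits. Compound 3 `Cc1cnsc1-c1ccccc1OCC1=NCCN1` differs from compound 2 by 4-methyl-1,2-thiazol-5-yl in place of 1,3-thiazol-2-yl on an aromatic carbon. Within the data shown here, no measured step tells how large such a change is, so the expectation rests on compound 2 alone. For compound 3 the expected step of a 2.5-fold higher number from compound 2 to compound 3 (0.40 log units; beyond the scatter) gives an estimate of 80 nM, with a range from 10 nM to 600 nM.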

Compound 3, half-maximal effective concentration: < 100000 nM
Compound 3: a limit, no number; the forecaster's own chance of this, stated with the estimate: 5%; the middle value is on the limit's open side.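

Neither the step from compound 2 to compound 3 nor the step from compound 1 to compound 3 can be read, because compound 3 gives only a limit, not a number: the limit of < 100000 nM in this assay, at which 2 of the 3 values shown sit.

The compounds shown leave open how much 4-methyl-1,2-thiazol-5-yl in place of 1,3-thiazol-2-yl changes the number.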